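This account rests on a few compounds, and the source may have more. Where it says the series, first, only, none or still open, it means among the compounds named here.

Within the data shown here, compound 2 `COc1cc(C2CC(=NOC(=O)c3ccc([N+](=O)[O-])cc3)CC(c3ccc(O)c(OC)c3)N2C)ccc1O` holds the highest of the two numbers so far in a functional assay on microsomes from liver (Rattus norvegicus, strain Wistar) for inhibition, read by spectrophotometry, with a stated time of 60 min (on this read-out higher numbers stand for weaker inhibition and lower numbers for stronger inhibition), where compound 2 gives 82000 nM. Compound 1 `COc1cc(C2CC(=NOC(=O)c3cccc(O)c3)CC(c3ccc(O)c(OC)c3)N2C)ccc1O` sits nearest, and in this assay compound 1 gives 25300 nM; the step of a 3.2-fold higher number from compound 1 to compound 2 (0.51 log units; beyond the scatter) is the only one measured. Compound 3 `COc1cc(C2CC(=NOC(=O)c3ccc(F)cc3)CC(c3ccc(O)c(OC)c3)N2C)ccc1O` differs from compound 2 by fluoro in place of nitro on an aromatic carbon. Among the measured compounds shown here, no measured step swaps groups on this ring, so the expected change is set loosely from the single step seen. A modestly lower number is expected for compound 3, about a 1.8-fold lower number from compound 2 to compound 3 (0.26 log units; within the scatter). The estimate for compound 3 in this assay is 45000 nM, within 15000 nM to 130000 nM.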

Compound 3, half-maximal inhibitory concentration: 140000 nM
For compound 3 the middle estimate is 3.1-fold (0.49 log units) below the measured one; measured number outside the range, above it.
By their numbers in this assay, from the lowest: compound 1; then compounds 2 and 3 (each within the scatter of the next).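

In this assay, fluoro in place of nitro on the aromatic carbon para to a large group gives a 1.7-fold higher number from compound 2 to compound 3 (0.23 log units; within the scatter), so this exchange at this position stays within the scatter. The change of 3-hydroxyphenyl to 4-fluorophenyl on the carbonyl carbon gives a 5.5-fold higher number from compound 1 to compound 3 (0.74 log units; beyond the scatter), which goes beyond the scatter in the same direction as a 3.2-fold higher number from compound 1 to compound 2 (0.51 log units; beyond the scatter), though each of these steps changes both the group and its ring position. Going by these compounds, whether an amine or a carboxylic acid on this aromatic carbon would move the number beyond the scatter remains open. No measurement at hand accounts for these numbers.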